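The source may hold more compounds than are shown below. What is called first, only, known or untested is meant among the compounds shown, and "the series" means these compounds.

Three compounds have been measured in an assay on isolated protein for inhibition of Rho-associated protein kinase 2 (Homo sapiens), read by scintillation counting, radiometric assay and 33P incorporation, with a stated time of 40 min, in the presence of a further agent that is not named here; on this read-out higher numbers stand for weaker inhibition and lower numbers for stronger inhibition:
compound 1, `COc1cccc(OCC(=O)Nc2cccc(NC(=O)c3ccc(N(C)C)cc3)c2)c1`, gives 5740 nM;
compound 2, `Cc1c(OCC(=O)Nc2cccc(NC(=O)c3ccc(N(C)C)cc3)c2)ccc2c(=O)ccoc12`, gives 4160 nM;
compound 3, `O=C(COc1ccc2c(=O)ccoc2c1)Nc1cccc(NC(=O)c2ccc(Br)cc2)c1`, gives 49 nM.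

Compound 3 has the lowest number of the three, and the gaps from it to compound 1 and to compound 2 both lie well beyond the scatter, so compound 3 is the strongest inhibitor among them.

Compound 4, `O=C(COc1ccc2c(=O)ccoc2c1)Nc1cccc(NC(=O)c2cnc(C(F)(F)F)s2)c1`, has not yet been measured. It differs from compound 3 in one place: 2-(trifluoromethyl)-1,3-thiazol-5-yl in place of 4-bromophenyl on a carbonyl carbon. For the measured compounds named here, no measured pair shows this change, so the data give no guide to its effect. The expected step from compound 3 to compound 4 is a 2.4-fold higher number from compound 3 to compound 4 (0.39 log units; beyond the scatter), a small move toward weaker inhibition that may stay within the scatter. Compound 4 is therefore estimated at 120 nM, expected to fall between 30 nM and 500 nM.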

Compound 4, half-maximal inhibitory concentration: 10 nM
Compound 4: middle estimate off by 12-fold (1.08 log units), on the high side; measured number below the stated range.
By their numbers in this assay, from the lowest: compound 4; then compound 3; then compounds 2 and 1 (each within the scatter of the next).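

The position on the carbonyl carbon is not limited to a six-membered aromatic ring of carbon only: a five-membered aromatic ring with 2 hetero atoms fits there too, and inhibition grows stronger, with a 4.9-fold lower number from compound 3 to compound 4 (0.69 log units; beyond the scatter) in favour of the new group. Nothing measured here accounts for this gain. The change replaces the ring and its substituent together, so the compounds shown leave open which of the two matters. A 4-(trifluoromethyl)phenyl group, or a 1,3-thiazol-5-yl ring carrying bromine instead of trifluoromethyl, would separate them.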